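Swapping an Aryl Ring for Ethyl on a Fused Core

This account rests on a few compounds, and the source may have more. Where it says the series, first, only, none or still open, it means among the compounds named here.

Compound 1, with the structure `O=C(N[C@H]1CCC[C@H](CO)C1)C1CCN(c2nc3cc(Cl)c(-c4cccc(Cl)c4)cc3o2)CC1`, is the starting point. For the measured compounds named here, in an ADME assay on microsomes from liver (Homo sapiens) for metabolic stability (on this read-out higher numbers stand for fast clearance and lower numbers for slow clearance), compound 1 gives 55.8 mL/min/kg, the highest of the two numbers so far. Its nearest neighbour is compound 2, with the structure `O=C(N[C@H]1CCC[C@H](CO)C1)C1CCN(c2nc3cc(Br)ccc3o2)CC1`; in this assay compound 2 gives 25.6 mL/min/kg, a lower number that lies beyond the usual scatter of repeated measurements.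

The next compound is compound 3, with the structure `CCc1cc2oc(N3CCC(C(=O)N[C@H]4CCC[C@H](CO)C4)CC3)nc2cc1Cl`. Compared with compound 1 it carries a different group on the fused core: ethyl in place of 3-chlorophenyl on an aromatic carbon.

Going by the values given here, no measured pair shows exactly this change, so any expectation rests on compound 1 and compound 2 alone. Because compound 2 gives 25.6 mL/min/kg with a smaller substituent pattern on the same core, a move toward slower clearance is expected, on the order of a 1.9-fold lower number from compound 1 to compound 3 (0.27 log units; within the scatter). For compound 3 the expected result in this assay is 30 mL/min/kg, with a likely range from 15 mL/min/kg to 60 mL/min/kg.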

Compound 3, clearance: 64.6 mL/min/kg
The estimate for compound 3 lay 2.2-fold (0.33 log units) below the measured number; the whole stated range lies below it.
By their numbers in this assay, from the lowest: compound 2; then compounds 1 and 3 (each within the scatter of the next).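

In this assay, putting ethyl in place of 3-chlorophenyl on this aromatic carbon gives a 1.2-fold higher number from compound 1 to compound 3 (0.06 log units; within the scatter) on an otherwise unchanged structure. At this position, then, a group of seven heavy atoms with an aromatic ring and a group of two carbons with no ring cannot be told apart on this read-out, so losing the ring does not by itself bring the clearance down. Nothing available explains why the number holds steady across this change.

As far as these compounds go, whether a bare hydrogen, a methyl, an amine or a carboxylic acid on this carbon would give a different number remains open. From the compounds shown here alone, compound 2 differs from compound 1 in more than one place, so which of those differences goes with its lower number also remains open.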